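The source may hold more compounds than are shown below. What is called first, only, known or untested is meant among the compounds shown, and "the series" means these compounds.

Working notes on the series. For the measured compounds named here, in an ADME assay on HEK293 cells (Homo sapiens) for cytotoxicity, read by MTT assay, with a stated time of 48 h (on this read-out lower numbers stand for stronger inhibition and higher numbers for weaker inhibition), compound 2 `Cc1ccc(S(=O)(=O)/N=C(/CCNC2=CC(=O)c3ccccc3C2=O)Nc2cc(F)c(F)c(F)c2)cc1` gives 82600 nM, the higher of the two numbers measured so far; its nearest neighbour is compound 1 `Cc1ccc(S(=O)(=O)/N=C(/CCNC2=CC(=O)c3ccccc3C2=O)Nc2ccc(F)c(F)c2)cc1`, which in this assay gives 55200 nM, and the two lie within the scatter of each other. Going by the values given here, the one measured step, a 1.5-fold higher number from compound 1 to compound 2 (0.18 log units; within the scatter), is a fluoro in place of hydrogen on an aromatic carbon and did not move the number beyond the scatter.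

Compound 3 `Cc1ccc(S(=O)(=O)/N=C(\N)CCNC2=CC(=O)c3ccccc3C2=O)cc1` is the next compound to be measured in this assay. It differs from compound 2 by hydrogen in place of 3,4,5-trifluorophenyl on an amine nitrogen, which removes the whole aryl group rather than altering one substituent on it; the measured step therefore bears on it only loosely, as a sign that changes to this part of the molecule have so far left this assay roughly unchanged. No step beyond the scatter is expected, though a modest rise cannot be excluded. Compound 3 is estimated at 100000 nM with a range of 40000 nM to 250000 nM, a step of a 1.2-fold higher number from compound 2 to compound 3 (0.08 log units; within the scatter).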

Compound 3, half-maximal inhibitory concentration: 63100 nM
Estimate against measurement, compound 3: 1.6-fold (0.20 log units) above, within the range that was stated.
By their numbers in this assay, from the lowest: compounds 1, 3 and 2 (each within the scatter of the next).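

In this assay, taking away the whole aryl group from the amine nitrogen gives a 1.3-fold lower number from compound 2 to compound 3 (0.12 log units; within the scatter), and the matching change on the difluorinated compound gives a 1.1-fold higher number from compound 1 to compound 3 (0.06 log units; within the scatter), both within the scatter. The earlier step covered only one added fluoro on the ring, whereas these two steps show that replacing the entire 3,4,5-trifluorophenyl or 3,4-difluorophenyl group with hydrogen also leaves the number within the scatter, so across these three compounds the aryl group on this nitrogen makes no measurable difference to the read-out. No supporting measurement is available to explain this flat response.

From the compounds shown here alone, it remains open whether this flat response holds for other groups on the same nitrogen, such as a methyl or acetyl group, or for an aryl ring carrying an amine or a carboxylic acid. All three compounds share the rest of the core, so they do not show how the number would respond to a change elsewhere, such as a longer chain leading to the amine nitrogen.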